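The compounds below may be only part of what the source reports. "The series", "measured", "known", "first", "only" and "open" are said of these compounds alone.

In a functional assay on the whole organism for inhibition, with Rattus norvegicus as the target, read by paw edema, with stated times of 4 days, 1 h and 2 h, at a dose of 100 mg/kg by the oral route (on this read-out higher numbers stand for more inhibition at the one dose given (going by the name of the read-out) and lower numbers for less inhibition), two compounds have been measured. Compound 1 `Brc1ccc2nc(-c3ccccc3)nc(N3CCC(c4ccccc4)CC3)c2c1` gives 57.6%, and compound 2 `CC1CCN(c2nc(-c3ccc(Cl)cc3)nc3ccc(Br)cc23)CC1` gives 55.1%. Compound 2 stands at the lower of the two numbers, but the gap to compound 1 lies within the usual scatter, so the two cannot be told apart on this read-out. Among the measured compounds shown here, compound 1 and compound 2 differ in two places, and no single step between them can be drawn.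

Compound 3 `Clc1ccc(-c2nc(N3CCC(c4ccccc4)CC3)c3cc(Br)ccc3n2)cc1` is not yet measured. It differs from compound 2 in one place: phenyl in place of methyl on a saturated ring carbon. Compound 1 carries the same phenyl on the saturated ring and gives 57.6%, a number not distinguished from that of compound 2. On that basis the step is expected to be a number 1.9 percentage points higher from compound 2 to compound 3 (within the scatter) in this assay, no change beyond the scatter in either direction. Compound 3 is therefore estimated to give 57%, within a range from 42% to 72%.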

Compound 3, a percentage reported as inhibition, in the whole organism at one dose (the size of the read-out at that dose, not a potency): 50%
Beside the measured number, compound 3's estimate is 7 percentage points above it; the measured number falls inside the stated range.
By their numbers in this assay, from the lowest: compounds 3, 2 and 1 (each within the scatter of the next).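

In this assay, the exchange of methyl for phenyl on a saturated ring carbon, three ring bonds from the ring nitrogen, can now be read directly as a number 5.1 percentage points lower from compound 2 to compound 3 (within the scatter) and so does not separate the two groups at this place on this read-out. The second single change, chloro in place of hydrogen on an aromatic carbon, reads as a number 7.6 percentage points lower from compound 1 to compound 3 (within the scatter) and likewise cannot be told apart from no change. Nothing in the information available bears on why these numbers stand where they do.

The compounds shown leave open whether an amine, a carboxylic acid or a longer chain on this saturated ring carbon would move the number beyond the scatter. With only methyl and phenyl compared there at a single dose, they also give no reading of potency.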